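Carboxylated amine tails: from compound 3 to compound 4

A few compounds are considered here, and "the series" means these few. Any claim that something is new, unique, unknown or untested is made for them only; others in the source may bear on it.

Compound 1 `COc1ccc(/C=C\c2cc(OC)c(OC)c(OC)c2)cc1OCc1ccc(CN2CC[C@H](C(=O)O)C2)cc1`: 6400 nM
Compound 2 `COc1ccc(/C=C\c2cc(OC)c(OC)c(OC)c2)cc1OCc1ccc(CN2CC(C(=O)O)C2)cc1`: > 10000 nM
Compound 3 `COc1ccc(/C=C\c2cc(OC)c(OC)c(OC)c2)cc1OCc1ccc(CN2CCCC[C@H]2C(=O)O)cc1`: > 10000 nM

In a functional assay on HepG2 cells (Homo sapiens) for antiproliferative activity, read by CCK-8 assay, with a stated time of 48 h (on this read-out lower numbers stand for stronger inhibition and higher numbers for weaker inhibition), compound 1 gives 6400 nM. For compound 2 the assay reports only a limit, > 10000 nM. For compound 3 the result is likewise only a limit, > 10000 nM. Compound 3 therefore stands at the ceiling of what this assay reports, a position it shares with one other member of the set (the limit of > 10000 nM in this assay, at which 2 of the 3 values shown sit), and no number separates it from compound 2.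

Compound 4 `COc1ccc(/C=C\c2cc(OC)c(OC)c(OC)c2)cc1OCc1ccc(CN[C@H](C(=O)O)[C@@H](C)O)cc1` is the next step from compound 3. The change is (1-carboxy-2-hydroxypropyl)amino in place of 2-carboxypiperidin-1-yl on a saturated chain carbon bound to an aromatic carbon.

For the measured compounds named here, two measured steps touch the same position. Both an at least 1.5-fold higher number from compound 1 to compound 2 (0.19 log units; that floor lies within the scatter) and an at least 1.5-fold higher number from compound 1 to compound 3 (0.19 log units; that floor lies within the scatter) run from a real number into a limit, so only their floors are known, and those floors lie within the scatter. The step that the two limits leave unreadable from compound 2 to compound 3 is unreadable, as both ends are limits. Going by the values given here, every variation of the carboxylated amine tail so far has either stayed near the upper edge of the assay or passed beyond it, so no step of readable size is expected in this assay from compound 3 to compound 4, and the most likely outcome for compound 4 is again a limit.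

The estimate for compound 4 is 12000 nM, within 5000 nM to 30000 nM, which corresponds to an expected step that the limit leaves unreadable from compound 3 to compound 4.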

Compound 4, half-maximal inhibitory concentration: > 10000 nM
Compound 4: no number, only a limit; the forecaster's own chance of this, stated with the estimate: 65%; the middle value lies beyond the limit too.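

In this assay, the position on a saturated chain carbon bound to an aromatic carbon now carries a tail with no ring, (1-carboxy-2-hydroxypropyl)amino, and compound 4 still returns only a limit, as the ring-bearing tails of compound 2 and compound 3 did. The ceiling is therefore not confined to tails with a ring, and the set now reads: the limit of > 10000 nM in this assay, at which 3 of the 4 values shown sit.

For the compounds shown here, the one step with a number at one end is an at least 1.5-fold higher number from compound 1 to compound 4 (0.19 log units; that floor lies within the scatter), so only its floor is known, while the steps among compound 2, compound 3 and compound 4 cannot be read, as both ends of each are limits. Going by these compounds alone, compound 1, with the 3-carboxypyrrolidin-1-yl tail, remains the only member of the set with a measured number, 6400 nM.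

How far compound 2, compound 3 and compound 4 lie past the ceiling stays open, so no order among these tails can be drawn. Also open, on these data alone, is how a methyl ester or a primary amide in place of the carboxylic acid on these tails, or a morpholine tail, would read in this assay.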